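The compounds below may be only part of what the source reports. "The series", "measured", "known", "first", "only" and "open" are said of these compounds alone.

Series notes. Compound 1 `O=CN1N=C(c2ccc(F)cc2)CC1c1cn(-c2ccccc2)nc1-c1ccc(Cl)c(Cl)c1` and compound 2 `CC(=O)N1N=C(c2ccc(F)cc2)CC1c1cn(-c2ccccc2)nc1-c1ccc(Cl)c(Cl)c1` share one core and differ only at a carbonyl carbon. In a functional assay on the whole organism (strain Wistar) for inhibition, with Rattus norvegicus as the target, read by paw edema, with a stated time of 30 min, at a dose of 50 mg/kg by the oral route (a higher number here means more inhibition at the dose given (going by the name of the read-out), a lower number less inhibition), compound 1 gives 37.2%, and compound 2 gives 45.7%. Among the measured compounds shown here, the single measured step, a number 8.5 percentage points higher from compound 1 to compound 2 (within the scatter), is methyl in place of hydrogen on a carbonyl carbon. On the numbers shown compound 2 sits at the top of the two, but the gap is within the scatter, so the two compounds cannot be separated in this assay. Compound 3 `O=[N+]([O-])c1ccc(N2N=C(c3ccc(F)cc3)CC2c2cn(-c3ccccc3)nc2-c2ccc(Cl)c(Cl)c2)cc1` is the next member; relative to compound 2 the change is 4-nitrophenyl in place of acetyl on an amine nitrogen in a ring. For the measured compounds named here, no measured step bears on this exchange: the methyl-for-hydrogen step concerns a different change, and nothing here shows what a 4-nitrophenyl on this ring nitrogen does. Going by the values given here, the only guidance is that the two measured compounds sit close together. Compound 3 is therefore expected near compound 2, with an expected step of a number 1.7 percentage points lower from compound 2 to compound 3 (within the scatter) that stays within the scatter. The estimate for compound 3 is 44%, with a range from 24% to 64%.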

Compound 3, a percentage reported as inhibition, in the whole organism at one dose (the size of the read-out at that dose, not a potency): 45.7%
Compound 3: the middle estimate sits 1.7 percentage points below what was measured; low and high end bracket the measured number.
By their numbers in this assay, from the lowest: compounds 1, 2 and 3 (each within the scatter of the next).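

In this assay the exchange of acetyl for 4-nitrophenyl on the amine nitrogen in a ring gives no change at the digits printed from compound 2 to compound 3 (within the scatter) and the exchange of formyl for 4-nitrophenyl gives a number 8.5 percentage points higher from compound 1 to compound 3 (within the scatter) at the same place. Until now this nitrogen carried only small carbonyl groups; the read-out now shows that a carbonyl there is not required and that a six-membered aromatic ring, with 9 heavy atoms entering in place of 3, is accepted at this dose. No supporting data explain this result.

As far as these compounds go, whether the nitro group contributes anything remains open, as a plain phenyl or a 4-aminophenyl on this nitrogen would show. Also open, from the compounds shown here alone, is how a longer alkyl chain or a group carrying a carboxylic acid would read at this position.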